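Taking the chloro group off compound 2

The source may hold more compounds than are shown below. What is called first, only, known or untested is meant among the compounds shown, and "the series" means these compounds.

Compound 1 `Nc1ccccc1NC(=O)c1ccc(COc2ccc([N+](=O)[O-])cc2)cc1` gives > 32000 nM (a limit of the assay)
Compound 2 `Nc1ccccc1NC(=O)c1ccc(COc2ccc(Cl)cc2)cc1` gives 17300 nM (a measured number)

For the measured compounds named here, in a functional assay on HCT-116 cells (Homo sapiens) for antiproliferative activity, read by CCK-8 assay, with a stated time of 72 h (a higher number here means a weaker inhibitor, a lower number a stronger inhibitor), compound 2 holds the only actual number so far, 17300 nM and so it has no second number to be ranked against. The reading for compound 1 is the limit of > 32000 nM in this assay, at which 1 of the 2 values shown sits, and it remains a limit.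

The next compound is compound 3 `Nc1ccccc1NC(=O)c1ccc(COc2ccccc2)cc1` which has hydrogen in place of chloro on an aromatic carbon, turning 4-chlorophenoxy into phenoxy: hydrogen in place of chloro on an aromatic carbon.

Going by the values given here, one measured step bears on this, since it changes the same aromatic carbon: an at least 1.8-fold lower number from compound 1 to compound 2 (0.26 log units; that floor lies within the scatter). It gives only a floor, and it involves nitro rather than hydrogen, so it offers no firm size or direction for the new change. On that thin evidence, no shift beyond the scatter is expected in this assay and any lean towards a higher number would be slight. The expected change is a 1.2-fold higher number from compound 2 to compound 3 (0.06 log units; within the scatter) as an estimate. Compound 3 is expected at 20000 nM within an estimated range of 9000 nM to 40000 nM for now.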

Compound 3, half-maximal inhibitory concentration: 4890 nM
Beside the measured number, compound 3's estimate is 4.1-fold (0.61 log units) above it, and the stated range ends above it.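

In this assay, this position now yields its first step beyond the scatter, and it runs against any expectation that a substituent here helps: a 3.5-fold lower number from compound 2 to compound 3 (0.55 log units; beyond the scatter). The earlier change on this aromatic carbon, from nitro to chloro, gave only a floor within the scatter, whereas replacing nitro with hydrogen gives an at least 6.5-fold lower number from compound 1 to compound 3 (0.81 log units; beyond the scatter), so both substituents shown, chloro and nitro, carry higher numbers than hydrogen, and compound 3, the phenoxy compound, is the strongest of the three. The size of that second step remains a floor, because the reading for compound 1 is a limit and not a number: the limit of > 32000 nM in this assay, at which 1 of the 3 values shown sits.

With only hydrogen, chloro and nitro shown on this carbon, it remains open how a fluoro, a methyl, a methoxy or an amine would read here, and so whether hydrogen's lead holds against smaller or differently built groups. From the compounds shown here alone, it is also open whether the gap between chloro and hydrogen would persist with changes elsewhere in the shared core, and what lies behind it.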